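The source may report more compounds than this note shows. Statements on the series, on what has been measured and on what is new or still open speak of the compounds shown alone.

- compound 1 `COc1cc(/C=C/C(=O)Nc2cc3c(Nc4ccc(F)c(Cl)c4)ncnc3cc2O[C@H]2CCOC2)cc(OC)c1OC`: 4150 nM
- compound 2 `COc1cc2ncnc(Nc3ccc(F)c(Cl)c3)c2cc1NC(=O)/C=C/c1ccc(C#N)cc1`: "not active" (no number reported)
- compound 3 `COc1cc(/C=C/C(=O)Nc2cc3c(Nc4ccc(F)c(Cl)c4)ncnc3cc2OC)cc(OC)c1`: "not active" (no number reported)

Going by the values given here, in a functional assay on A549 cells (Homo sapiens) for cytotoxicity, read by MTT assay, with a stated time of 72 h (on this read-out higher numbers stand for weaker inhibition and lower numbers for stronger inhibition), compound 1 gives 4150 nM as the only number available, while compound 2 and compound 3 come without any number. Compound 4 `O=C(/C=C/c1ccccc1[N+](=O)[O-])Nc1cc2c(Nc3ccc(F)c(Cl)c3)ncnc2cc1O[C@H]1CCOC1` has not yet been measured. The change from compound 1 is 2-nitrophenyl in place of 3,4,5-trimethoxyphenyl on a double-bonded chain carbon bound to a double-bonded chain carbon and amounts to 2-nitrophenyl in place of 3,4,5-trimethoxyphenyl on a double-bonded chain carbon bound to a double-bonded chain carbon. Among the compounds with values here, no two measured compounds differ in one place only, so the expectation rests on little. A small step toward weaker inhibition is expected in this assay and may stay within the scatter. The estimated move is a 1.4-fold higher number from compound 1 to compound 4 (0.16 log units; within the scatter) and no more than that is expected. Compound 4 is estimated at 6000 nM with an expected range from 1800 nM to 25000 nM as its span.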

Compound 4, half-maximal inhibitory concentration: 8820 nM
Compound 4: the middle estimate sits 1.5-fold (0.17 log units) below what was measured, and the stated range covers the measured number.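

In this assay this position gives its first readable step: 2-nitrophenyl in place of 3,4,5-trimethoxyphenyl on a double-bonded chain carbon brings a 2.1-fold higher number from compound 1 to compound 4 (0.33 log units; beyond the scatter) as a modest change. The exchange therefore weakens inhibition only slightly, and compound 4 still gives a number. Nothing measured here explains this step.

On these data alone, whether the step comes from losing the methoxy groups or from gaining the nitro group stays open. So does the effect of a phenyl ring bearing an amine or a carboxylic acid at this position.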